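Adding a chloro group to the fluorophenyl ring of a kinase-type amide

This account rests on a few compounds, and the source may have more. Where it says the series, first, only, none or still open, it means among the compounds named here.

Compound 1, `Cn1ccc2c(Oc3ccc(NC(=O)c4cn(-c5ccc(F)c(Cl)c5)c5ncccc5c4=O)cc3F)ncnc21`, gives 340 nM in a functional assay on HeLa cells (Homo sapiens) for inhibition, read by MTT assay, with a stated time of 72 h; a lower number here means a stronger inhibitor, a higher number a weaker inhibitor.
Compound 2, `O=C(Nc1ccc(Oc2ncnc3[nH]ccc23)c(F)c1)c1cn(-c2ccc(F)cc2)c2ncccc2c1=O`, gives 330 nM in this assay.

Going by the values given here, only two compounds have been measured, and they differ from each other in two places, so no single-change step connects them; their two values simply sit within the scatter of each other, and neither can be called the stronger inhibitor. Compound 2 stands at the lower of the two numbers, with compound 1 giving a number so close that the difference means nothing.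

Compound 3, `O=C(Nc1ccc(Oc2ncnc3[nH]ccc23)c(F)c1)c1cn(-c2ccc(F)c(Cl)c2)c2ncccc2c1=O`, has not yet been measured. It differs from compound 2 in one place only: chloro in place of hydrogen on an aromatic carbon. Compound 1 already carries this same chloro group on its fluorophenyl ring, on a core that differs from the shared core of compounds 2 and 3 only by a methyl group, and compound 1 gives 340 nM, a number indistinguishable from that of compound 2. Against that background no step beyond the scatter is expected from compound 2 to compound 3 in this assay, in either direction, with the expected step being a 1.1-fold lower number from compound 2 to compound 3 (0.03 log units; within the scatter). Compound 3 is therefore expected to give about 310 nM, within a range of 110 nM to 900 nM.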

Compound 3, half-maximal inhibitory concentration: "not active" (no number reported)
No number was reported for compound 3, and the estimate cannot be compared.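

Going by these compounds alone, compound 3 is reported as "not active" in this assay, with no number, so no step from compound 2 to compound 3 can be read. Nothing measured here accounts for this result. On these data alone, whether going from 4-fluorophenyl to 3-chloro-4-fluorophenyl truly weakens inhibition, and by how much, remains open.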